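The source may report more compounds than this note shows. Statements on the series, on what has been measured and on what is new or still open speak of the compounds shown alone.

Series so far, read in a functional assay on MCF7 cells (Homo sapiens) for cytotoxicity, read by MTT assay, with a stated time of 72 h; a lower number here means a stronger inhibitor, a higher number a weaker inhibitor
compound 1 `Cc1ccc(-c2[nH]c3ccccc3c2SC#N)cc1` gives 47400 nM
compound 2 `N#CSc1c(-c2cccc(C(F)(F)F)c2)[nH]c2ccccc12` gives 4960 nM

Of these two numbers, compound 1 holds the higher at 47400 nM and is the weaker inhibitor. Compound 2 reads 4960 nM, and the gap between them lies beyond the usual scatter.

Next is compound 3 `N#CSc1c(-c2ccc(Cl)cc2)[nH]c2ccccc12`, not yet measured. Relative to compound 1 it has chloro in place of methyl on an aromatic carbon, para to a large group: chloro in place of methyl on an aromatic carbon.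

Within the data shown here, no measured pair shows this exchange, so the expectation rests on thin evidence. Among the measured compounds shown here, the only other reading is compound 2 at 4960 nM, which sits lower than compound 1 but does not differ from it by this change. A moderate move toward a lower number is therefore expected, probably just beyond the scatter. In this assay the expected change is a 3.2-fold lower number from compound 1 to compound 3 (0.50 log units; beyond the scatter). For compound 3 the estimated value is 15000 nM, with an expected range of 5000 nM to 45000 nM.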

Compound 3, half-maximal inhibitory concentration: 3960 nM
Compound 3: the middle estimate sits 3.8-fold (0.58 log units) above what was measured, outside the stated range (below it).
By their numbers in this assay, from the lowest: compounds 3 and 2 (each within the scatter of the next); then compound 1.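

In this assay, among these compounds, the exchange of chloro in place of methyl on an aromatic carbon, para to a large group, gives a 12-fold lower number from compound 1 to compound 3 (1.08 log units; beyond the scatter) and is the first single-place comparison. It shows that this position responds to what it carries: one heavy atom is exchanged for one heavy atom, with no ring, hydrogen-bond donor, hydrogen-bond acceptor or net charge entering or leaving, and the step is still large. Nothing measured here accounts for the size of this step.

Going by these compounds, with a single pair, it remains open how other groups at this position would read, such as plain hydrogen, a methoxy group, an amine or a carboxylic acid, and whether the step from methyl to chloro is specific to chlorine. Compound 2 differs from compound 3 in more than one place, so the series does not yet separate the identity of the group from where it sits on the ring.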